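N-Methylation of the Fused Core: An Untested Step

The source may report more compounds than this note shows. Statements on the series, on what has been measured and on what is new or still open speak of the compounds shown alone.

Measured so far:
Compound 1 `O=C(Nc1ccc(Oc2ccnc3[nH]ccc23)c(F)c1)c1nn(-c2ccc(Cl)c(F)c2)ccc1=O` gives 11600 nM in a functional assay on MCF7 cells (Homo sapiens) for cytotoxicity, read by MTT assay, with a stated time of 72 h; on this read-out higher numbers stand for weaker inhibition and lower numbers for stronger inhibition.
Compound 2 `O=C(Nc1ccc(Oc2ccnc3[nH]ccc23)c(F)c1)c1nn(-c2ccc(Cl)c(C(F)(F)F)c2)ccc1=O` gives 11600 nM in this assay.

Compound 1 stands level with compound 2 at the digits shown: the one recorded step, no change at the digits printed from compound 1 to compound 2 (within the scatter), changed the substituent on the outer aromatic ring without moving the read-out beyond the usual scatter.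

Compound 3 `Cn1ccc2c(Oc3ccc(NC(=O)c4nn(-c5ccc(Cl)c(F)c5)ccc4=O)cc3F)ccnc21` has not yet been measured. It differs from compound 1 by methyl in place of hydrogen on an aromatic nitrogen. This change sits on the fused ring system of the shared core, far from the outer aromatic ring that was varied between compound 1 and compound 2. Among the measured compounds shown here, no measured step touches this position, so the only recorded step, no change at the digits printed from compound 1 to compound 2 (within the scatter), does not bear on it directly; it shows merely that one distant change left the read-out unmoved. In the absence of a relevant comparison the working expectation is a step of no change at the digits printed from compound 1 to compound 3 (within the scatter), that is, no shift beyond the scatter, though with considerable uncertainty. Compound 3 is therefore estimated at 11600 nM in this assay, expected between 4000 nM and 35000 nM.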

Compound 3, half-maximal inhibitory concentration: 16600 nM
Compound 3: the middle estimate sits 1.4-fold (0.16 log units) below what was measured, and the stated range covers the measured number.
By their numbers in this assay, from the lowest: compounds 1, 2 and 3 (each within the scatter of the next).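

Among the compounds shown here, until now, the only recorded step lay on the outer aromatic ring, leaving the shared core untested. In this assay, methyl in place of hydrogen on an aromatic nitrogen of the five-membered aromatic ring gives a 1.4-fold higher number from compound 1 to compound 3 (0.16 log units; within the scatter), which shows that this one change on the core, like the earlier change on the outer ring, leaves the read-out within the usual scatter of repeated measurements. No separate measurement is at hand to explain this result.

The compounds shown leave open whether something larger than methyl on this nitrogen, such as an ethyl group, a longer chain ending in an amine, or a chain carrying a carboxylic acid, would also leave the read-out where it stands or would shift it in either direction. Also open, from the compounds shown here alone, is whether the same methyl would have as small an effect on compound 2, which carries trifluoromethyl in place of fluoro on the outer aromatic ring.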